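Benzyl substituent exchange in a pair at the assay limit

This account rests on a few compounds, and the source may have more. Where it says the series, first, only, none or still open, it means among the compounds named here.

Compound 1, `CCCCCCCCCCCCCCCC(NCc1cccc(Cl)c1)=C1C(=O)OC(CO)C1=O`: in an assay on isolated protein for inhibition of dual specificity protein phosphatase 6 (Homo sapiens) (a higher number here means a weaker inhibitor, a lower number a stronger inhibitor), compound 1 gives > 100000 nM, a limit of the assay.
Compound 2, `CCCCCCCCCCCCCCCC(NCc1ccc(C)cc1)=C1C(=O)OC(CO)C1=O`: compound 2 gives > 100000 nM, likewise a limit.

Both values are limits, not numbers, so the step that the two limits leave unreadable from compound 1 to compound 2 cannot be read. Compound 2 stands at the limit of > 100000 nM in this assay, at which 2 of the 2 values shown sit. Compound 3, `CCCCCCCCCCCCCCCC(NCc1ccc(N(C)C)cc1)=C1C(=O)OC(CO)C1=O`, differs from compound 2 by dimethylamino in place of methyl on an aromatic carbon. Among the measured compounds shown here, no measured step bears readably on this change, and neither measured value gives a direction. Compound 3 is expected to remain at the limit, so the expected step of a number no higher from compound 2 to compound 3 (the limit leaves the size open) shows nothing beyond the scatter. Compound 3 is estimated at 100000 nM, ranging from 30000 nM to 300000 nM.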

Compound 3, half-maximal inhibitory concentration: > 100000 nM
Compound 3: no number, only a limit; the forecaster's own chance of this, stated with the estimate: 75%; the middle value sits exactly at the limit.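

Among the compounds shown here, compound 3 gives > 100000 nM, a limit of the assay, so no step among compound 1, compound 2 and compound 3 can be read. The compounds shown leave open whether any benzyl substituent gives a readable value in this assay.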